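This account rests on a few compounds, and the source may have more. Where it says the series, first, only, none or still open, it means among the compounds named here.

Of the compounds shown here, three of this set have been measured in an ADME assay on L02 cells (Homo sapiens) for cytotoxicity, read by MTT assay, with a stated time of 24 h; a higher number here means a weaker inhibitor, a lower number a stronger inhibitor. Compound 1 `O=C1/C(=C/c2ccccc2F)CN(S(=O)(=O)c2ccc(Br)cc2)C/C1=C\c1ccccc1F` gives 16200 nM in this assay. Compound 2 `N#Cc1ccc(S(=O)(=O)N2C/C(=C\c3ccccc3F)C(=O)/C(=C/c3ccccc3F)C2)cc1` carries the change cyano in place of bromo on an aromatic carbon and gives 11000 nM in this assay; the step of a 1.5-fold lower number from compound 1 to compound 2 (0.17 log units; within the scatter) lies within the scatter. Compound 3 `O=C1/C(=C/c2cccc(F)c2)CN(S(=O)(=O)c2ccc(Br)cc2)C/C1=C\c1cccc(F)c1` has the same atoms as compound 1, joined differently, in a way that is not broken down here. In this assay compound 3 gives 15800 nM; its number and those of compound 1 and compound 2 all lie within the scatter of one another, so no order among them can be read.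

Compound 4 `N#Cc1ccc(S(=O)(=O)N2C/C(=C\c3cccc(F)c3)C(=O)/C(=C/c3cccc(F)c3)C2)cc1` has not yet been measured. Going by the values given here, it differs from compound 3 by cyano in place of bromo on an aromatic carbon, which is the same change as the one from compound 1 to compound 2, placed in the same way in both pairs. Because the step of a 1.5-fold lower number from compound 1 to compound 2 (0.17 log units; within the scatter) lies within the scatter, a step of similar size is expected here, a 1.5-fold lower number from compound 3 to compound 4 (0.17 log units; within the scatter). Compound 4 is therefore estimated at 10800 nM in this assay, with a range from 6500 nM to 18000 nM.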

Compound 4, half-maximal inhibitory concentration: 15500 nM
For compound 4 the middle estimate is 1.4-fold (0.16 log units) below the measured one; measured number inside the range.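

In this assay, cyano in place of bromo on an aromatic carbon gives a 1.0-fold lower number from compound 3 to compound 4 (0.01 log units; within the scatter), so this step too can be read only as lying within the scatter. Set beside the earlier step, the new one agrees with it, and the two cores give no sign of handling the change differently: the same change on two cores in this assay, a 1.5-fold lower number (0.17 log units; within the scatter) from compound 1 to compound 2 and a 1.0-fold lower number (0.01 log units; within the scatter) from compound 3 to compound 4, 1.4-fold (0.16 log units) apart, within the scatter of two such steps

This shows that, across these two pairs, the change carries from one core to the other without a readable difference, but it does not show that the change has any effect of its own on the number, since the agreement is between two steps that are each within the scatter, and two pairs say nothing about a further core.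

The compounds shown leave open whether another group at this place, such as an amine or a carboxylic acid, would give a step beyond the scatter. They also leave open what chloro or methoxy in place of the fluoro groups would do to the number.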